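Swapping Fluorine for Methoxy on a Thiazolidinedione Series

The source may hold more compounds than are shown below. What is called first, only, known or untested is meant among the compounds shown, and "the series" means these compounds.

Three compounds sharing one core were tested in a functional assay on MCF7 cells (Homo sapiens), tested at 7.5 uM; a higher number here means a weaker effect of the compound at the concentration tested, a lower number a stronger effect. Compound 1 `CC(C)=CCOc1c(C)c(C)c2c(c1C)CCC(C)(COc1ccc(/C=C3\SC(=O)NC3=O)cc1F)O2` gives 64%, the second highest of the three numbers. Its nearest neighbour is compound 2 `C=CCOc1c(C)c(C)c2c(c1C)CCC(C)(COc1ccc(/C=C3\SC(=O)NC3=O)cc1OCC)O2`, which gives 75%, a number higher by more than the usual scatter. The furthest is compound 3 `Cc1c(C)c2c(c(C)c1OCc1ccccc1)CCC(C)(COc1ccc(/C=C3\SC(=O)NC3=O)cc1)O2`, which in this assay gives 12%, far lower and beyond the scatter.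

Compound 4 `COc1cc(/C=C2\SC(=O)NC2=O)ccc1OCC1(C)CCc2c(C)c(OCC=C(C)C)c(C)c(C)c2O1` has not yet been measured. Compared with compound 1 the change is methoxy in place of fluoro on an aromatic carbon. Among the measured compounds shown here, with no step between measured compounds involving only this change, the expected shift from compound 1 is small, a number 4 percentage points higher from compound 1 to compound 4 (within the scatter), possibly none beyond the scatter. Compound 4 is therefore estimated at 68%, within a range of 45% to 90%.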

Compound 4, a percentage reported as activity, at one concentration (the size of the read-out at that concentration, not a potency): 54%
Estimate against measurement, compound 4: 14 percentage points above; the measured number falls inside the stated range.
By their numbers in this assay, from the lowest: compound 3; then compounds 4 and 1 (each within the scatter of the next); then compound 2.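

Among the compounds shown here, this is the first reading of a single change at this position, on an aromatic carbon ortho to a large group. In this assay, methoxy in place of fluoro gives a number 10 percentage points lower from compound 1 to compound 4 (within the scatter) and so shows no change beyond the scatter, even though methoxy brings one more heavy atom and a hydrogen-bond acceptor. No measurement here offers an explanation for this result.

Going by these compounds, whether an amine, a carboxylic acid or a longer chain at this position would move the number beyond the scatter remains open.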